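The source may hold more compounds than are shown below. What is called first, only, known or untested is meant among the compounds shown, and "the series" means these compounds.

Measured compounds:
Compound 1, `COc1ccc(CNc2cc(OC)c(OC)c(OC)c2)cc1Cl`: 47800 nM
Compound 2, `COc1cc(NCc2ccc(Cl)cc2)cc(OC)c1OC`: > 80000 nM
Compound 3, `COc1ccc(CNc2cc(OC)c(OC)c(OC)c2)cc1Br`: 39800 nM

Three compounds were tested in a functional assay on KYSE-450 cells (Homo sapiens) for inhibition, read by MTT assay, with a stated time of 48 h; a lower number here means a stronger inhibitor, a higher number a weaker inhibitor. Compound 1 gives 47800 nM in this assay. Compound 3 gives 39800 nM. For compound 2 the assay reports only a limit, > 80000 nM, and no number. This limit is where one of the three values sits (the limit of > 80000 nM in this assay, at which 1 of the 3 values shown sits).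

Compound 1 and compound 3 differ in one place: bromo in place of chloro on an aromatic carbon. The step between them, a 1.2-fold lower number from compound 1 to compound 3 (0.08 log units; within the scatter), is within the scatter of the measurement. The difference between the core of compound 1 and the core of compound 2 is not broken down here.

Compound 4, `COc1cc(NCc2ccc(Br)cc2)cc(OC)c1OC`, has not been measured in this assay. It differs from compound 2 in one place: bromo in place of chloro on an aromatic carbon. Among the measured compounds shown here, this is the same kind of change as the one from compound 1 to compound 3, though the surroundings of the place are not the same: in compound 3 the bromo sits ortho to a methoxy group and meta to a large group, while in compound 4 it sits para to a large group.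

Since the earlier change left the value essentially unmoved, a similarly small step is expected here, so the value of compound 4 is estimated as a number no higher from compound 2 to compound 4 (the limit leaves the size open). Because compound 2 itself sits at the limit (the limit of > 80000 nM in this assay, at which 1 of the 3 values shown sits), compound 4 is expected to be weak as well, and may again be reported only as a limit. The estimate for compound 4 is 80000 nM, with a range from 40000 nM to 160000 nM.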

Compound 4, half-maximal inhibitory concentration: > 80000 nM
Compound 4 was reported as a limit; the forecaster's own chance of this, stated with the estimate: 60%; the middle value lies on the limit itself.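

Compound 2 and compound 4 both stand at a limit in this assay, so the step between them, 4-chlorophenyl to 4-bromophenyl, cannot be read: the limit of > 80000 nM in this assay, at which 2 of the 4 values shown sit.

The compounds shown leave open what numbers compound 2 and compound 4 would give, and whether bromo in place of chloro acts on the core of compound 2 as it does on the core of compound 1.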